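A few compounds are considered here, and "the series" means these few. Any claim that something is new, unique, unknown or untested is made for them only; others in the source may bear on it.

In an assay on LX2 cells for inhibition of COL1A1 promoter (Homo sapiens), read by a luciferase reporter, with a stated time of 24 h, tested at 50 uM (on this read-out lower numbers stand for a weaker effect and higher numbers for a stronger effect at the one concentration tested), the three measured compounds gave the following:

Compound 1 `Cc1ccc(-n2cc(C(=O)Nc3cc(F)cc(F)c3)c(=O)c3ccc(N(C)C)nc32)cc1OCCCCCCC[N+]1(C)CCCC1` gives 55.9%.
Compound 2 `CN(C)c1ccc2c(=O)c(C(=O)Nc3cc(F)cc(F)c3)cn(-c3ccc(Cl)c(OCCCCCCC[N+]4(C)CCCC4)c3)c2n1` gives 76.1%.
Compound 3 `CC[N+]1(CCCCCCCOc2cc(C)cc(-n3cc(C(=O)Nc4cc(F)cc(F)c4)c(=O)c4ccc(N(C)C)nc43)c2)CCCCC1` gives 86.6%.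

Compound 2 stands second highest of these three numbers. Compound 3 shows a higher value, beyond the scatter, and compound 1 a lower one: the step of a number 20.2 percentage points higher from compound 1 to compound 2 (beyond the scatter) goes with a chloro in place of a methyl on an aromatic carbon.

Compound 4 `CN1CC[N+](C)(CCCCCCCOc2cc(-n3cc(C(=O)Nc4cc(F)cc(F)c4)c(=O)c4ccc(N(C)C)nc43)ccc2Cl)CC1` differs from compound 2 in one place: a group of 8 heavy atoms (6 carbon, 2 nitrogen; one six-membered non-aromatic ring with 2 hetero atoms) in place of a group of 6 heavy atoms (5 carbon, 1 nitrogen; one five-membered non-aromatic ring with 1 hetero atom), on a saturated chain carbon, seven bonds along the chain from an oxygen on an aromatic ring. The charged ring head at the end of the chain is thus exchanged, while the chloro and everything else in the shared core stay as in compound 2.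

For the measured compounds named here, none of the measured steps bears on this change. Going by the values given here, the only step recorded, a number 20.2 percentage points higher from compound 1 to compound 2 (beyond the scatter), concerns the aromatic substituent, not the chain end. Compound 3 carries a different chain head and a methyl on the aromatic ring, so it differs from compound 2 in more than one place, and its value shows only that such a head can go with a high number. Among the compounds with values here, with no step that tells how this exchange acts, the expected step of a number 0.1 percentage points lower from compound 2 to compound 4 (within the scatter) is estimated to lie within the scatter. Compound 4 is therefore expected to give 76%, in a range from 60% to 90%.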

Compound 4, a percentage reported as inhibition, at one concentration (the size of the read-out at that concentration, not a potency): 45.2%
For compound 4 the middle estimate is 30.8 percentage points above the measured one; the whole stated range lies above it.
By their numbers in this assay, from the lowest: compound 4; then compound 1; then compound 2; then compound 3.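

In this assay the group at the end of the chain proves to matter: a number 30.9 percentage points lower from compound 2 to compound 4 (beyond the scatter) goes with the exchange of a five-membered non-aromatic ring with 1 hetero atom for a six-membered non-aromatic ring with 2 hetero atoms. The place seven bonds along the chain from an oxygen on an aromatic ring is therefore not indifferent to what it carries, even though the group that leaves and the group that enters both have a net charge of +1 and the shared core stays the same. Nothing measured here tells which of the differences between the two groups, whether ring size, the second nitrogen or the added hydrogen-bond acceptor, goes with the lower number.

Still open, as far as these compounds go, is how a piperidine ring with a single nitrogen, or a morpholine ring with an oxygen in place of the second nitrogen, would read at the same chain end, since either would help separate the effect of ring size from that of the second ring nitrogen. From the compounds shown here alone, it is also open whether the same exchange would give a step of similar size with a methyl in place of the chloro on the aromatic ring, or with a shorter chain.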